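The source may hold more compounds than are shown below. What is called first, only, known or untested is meant among the compounds shown, and "the series" means these compounds.

Measured so far:
compound 1, `O=S(=O)(NCCCCNCc1ccc(Br)cc1)c1cc(C(F)(F)F)cc(C(F)(F)F)c1`: 2900 nM
compound 2, `O=S(=O)(NCCCNCc1ccc(Cl)c(C(F)(F)F)c1)c1cc(C(F)(F)F)cc(C(F)(F)F)c1`: 9600 nM
compound 3, `COc1ccc(CNCCCNS(=O)(=O)c2cc(C(F)(F)F)cc(C(F)(F)F)c2)cc1`: 2800 nM

Read-out throughout is a functional assay on ASPC1 cells (Homo sapiens) for inhibition, read by MTT assay, with a stated time of 72 h; on this read-out higher numbers stand for weaker inhibition of growth and lower numbers for stronger inhibition of growth. Compound 3 has the lowest of the three numbers, but its gap to compound 1 is within the scatter; only compound 2 stands clearly apart from it.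

Compound 4, `COc1cccc(CNCCCNS(=O)(=O)c2cc(C(F)(F)F)cc(C(F)(F)F)c2)c1`, differs from compound 3 by 3-methoxyphenyl in place of 4-methoxyphenyl on a saturated chain carbon bound to an amine nitrogen. The measured steps that touch the same place are a 1.0-fold lower number from compound 1 to compound 3 (0.02 log units; within the scatter) and a 3.4-fold lower number from compound 2 to compound 3 (0.54 log units; beyond the scatter); both exchange the whole aryl group on the saturated chain carbon bound to the amine nitrogen, and neither keeps the same substituent while altering only its substitution pattern. Such a change has no precedent in this series, so no step beyond the scatter is expected, the estimated step being a 1.3-fold higher number from compound 3 to compound 4 (0.10 log units; within the scatter). Compound 4 is therefore estimated at 3500 nM, within 1500 nM to 8500 nM.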

Compound 4, concentration for 50% growth inhibition: 3800 nM
The estimate for compound 4 lay 1.1-fold (0.04 log units) below the measured number; low and high end bracket the measured number.
By their numbers in this assay, from the lowest: compounds 3, 1 and 4 (each within the scatter of the next); then compound 2.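

In this assay moving the methoxy group, 4-methoxyphenyl to 3-methoxyphenyl, gives a 1.4-fold higher number from compound 3 to compound 4 (0.13 log units; within the scatter) and shows that this position accepts the shift, which the earlier whole-aryl exchanges did not test. The second methoxy isomer also stands apart from the chloro and trifluoromethyl aryl group, with a 2.5-fold lower number from compound 2 to compound 4 (0.40 log units; beyond the scatter) as the gap. With a 1.3-fold higher number from compound 1 to compound 4 (0.12 log units; within the scatter) there is no separation from the bromobenzyl compound either.

From the compounds shown here alone, whether an ethoxy or hydroxy group on the same ring would hold this level remains open. No measurement at hand explains why both methoxy compounds sit apart from compound 2.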